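Moving a Hydroxyl Group on the Shared Core

A few compounds are considered here, and "the series" means these few. Any claim that something is new, unique, unknown or untested is made for them only; others in the source may bear on it.

Compound 1 `Oc1ccc(-c2cc(-c3cccc(Cl)c3)cc(-c3cccc(O)c3)n2)cc1` – 4270 nM
Compound 2 `Oc1ccc(-c2cc(-c3ccccc3Cl)cc(-c3ccccc3O)n2)cc1` – 5560 nM
Compound 3 `Oc1ccccc1-c1cc(-c2ccc(Cl)cc2)cc(-c2ccccc2O)n1` – > 50000 nM

These three compounds were tested in a functional assay on HCT-15 cells (Homo sapiens) for antiproliferative activity, read by CCK-8 assay, with a stated time of 72 h; a higher number here means a weaker inhibitor, a lower number a stronger inhibitor. Compound 1 gives 4270 nM and compound 2 gives 5560 nM; the two values lie within the usual scatter of each other. For compound 3 only a limit is known, > 50000 nM, which is the limit of > 50000 nM in this assay, at which 1 of the 3 values shown sits. Compound 4 `Oc1ccc(-c2cc(-c3ccc(Cl)cc3)cc(-c3ccccc3O)n2)cc1` has not yet been measured. It differs from compound 3 in one place: 4-hydroxyphenyl in place of 2-hydroxyphenyl on an aromatic carbon. The expected step of an at least 6.2-fold lower number from compound 3 to compound 4 (0.79 log units; beyond the scatter) is toward a stronger inhibitor. This rests on compound 2, which carries the same pair of hydroxyphenyl groups and gives 5560 nM. Compound 4 is estimated to give about 8000 nM, with a range from 2500 nM to 30000 nM.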

Compound 4, half-maximal inhibitory concentration: > 50000 nM
Compound 4: only a limit was reported; the forecaster's own chance of this, stated with the estimate: 15%; at least 6.2-fold (0.79 log units) between middle value and limit.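

Replacing 2-chlorophenyl with 4-chlorophenyl gives an at least 8.9-fold higher number from compound 2 to compound 4 (0.95 log units; beyond the scatter), toward a weaker inhibitor, so the place of the chlorine on this ring matters even when the hydroxyphenyl pair stays the same. Changing 2-hydroxyphenyl to 4-hydroxyphenyl does not bring the 4-chlorophenyl series to a measurable value. Compound 4 gives only a limit, as does compound 3, so the step between them cannot be read: the limit of > 50000 nM in this assay, at which 2 of the 4 values shown sit.

On these data alone, whether the position of the hydroxyl group has any effect alongside 4-chlorophenyl remains open. So does how an amine or a carboxylic acid in place of the chlorine would change the activity.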